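Ring opening at the aromatic amine of compound 3

A few compounds are considered here, and "the series" means these few. Any claim that something is new, unique, unknown or untested is made for them only; others in the source may bear on it.

Compound 3 `N=S1(=O)CC(Nc2nonc2/C(=N/O)Nc2ccc(F)c(Br)c2)C1` stands second highest of the three numbers measured in an assay on isolated protein for inhibition of Indoleamine 2,3-dioxygenase 1 (Homo sapiens), read by fluorescence, with a stated time of 60 min (on this read-out lower numbers stand for stronger inhibition and higher numbers for weaker inhibition), where compound 3 gives 208 nM. Nearest to it is compound 1 `[O-][S+]1CC(Nc2nonc2/C(=N/O)Nc2ccc(F)c(Br)c2)C1`, which in this assay gives 212 nM; the two sit together, with a 1.0-fold lower number from compound 1 to compound 3 (0.01 log units; within the scatter). Compound 2 `O=S1(=O)CC(Nc2nonc2/C(=N/O)Nc2ccc(F)c(Br)c2)C1` gives 99 nM, the lowest number of the three, reached by a 2.1-fold lower number from compound 1 to compound 2 (0.33 log units; beyond the scatter) and separated from compound 3 by a 2.1-fold higher number from compound 2 to compound 3 (0.32 log units; beyond the scatter).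

Compound 4 `CCNS(=O)(=O)CCNc1nonc1/C(=N/O)Nc1ccc(F)c(Br)c1` carries the change (a group of 8 heavy atoms (4 carbon, 1 nitrogen, 2 oxygen, 1 sulfur; no ring) in place of a group of 6 heavy atoms (3 carbon, 1 nitrogen, 1 oxygen, 1 sulfur; one four-membered non-aromatic ring with 1 hetero atom), on a nitrogen on an aromatic ring). The three measured steps all sit on the same nitrogen and only exchange one four-membered ring for another; the largest of them, a 2.1-fold lower number from compound 1 to compound 2 (0.33 log units; beyond the scatter), is modest, and a 1.0-fold lower number from compound 1 to compound 3 (0.01 log units; within the scatter) lies within the scatter. Going by the values given here, no measured step opens the ring or lengthens the chain, so the present change is not directly covered. Compound 4 is expected to move by about a 1.1-fold higher number from compound 3 to compound 4 (0.02 log units; within the scatter), with no clear direction beyond the scatter. The estimate for compound 4 in this assay is 220 nM, within a range from 80 nM to 600 nM.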

Compound 4, half-maximal inhibitory concentration: 95 nM
For compound 4 the middle estimate is 2.3-fold (0.36 log units) above the measured one; the range from low to high includes it.
By their numbers in this assay, from the lowest: compounds 4 and 2 (each within the scatter of the next); then compounds 3 and 1 (each within the scatter of the next).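

Working notes: in this assay, the open 2-(ethylsulfamoyl)ethyl chain on the nitrogen on an aromatic ring is accepted in place of the four-membered ring, with modest gains in both a 2.2-fold lower number from compound 3 to compound 4 (0.34 log units; beyond the scatter) and a 2.2-fold lower number from compound 1 to compound 4 (0.35 log units; beyond the scatter). Set against the ring of compound 2, the chain makes no difference beyond the scatter, with a 1.0-fold lower number from compound 2 to compound 4 (0.02 log units; within the scatter), so a ring at this position is not required to reach the lowest numbers in this set. No measurement is available to explain these steps.

Still open, going by these compounds, is whether the ethyl on the sulfamoyl nitrogen contributes, which a methyl or a longer chain there would test. Also open, on these data alone, is whether the sulfamoyl group itself can be replaced by a carboxylic acid or an amine on the same chain.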